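A Chain Extension That Outruns the Assay Window

This account rests on a few compounds, and the source may have more. Where it says the series, first, only, none or still open, it means among the compounds named here.

Four compounds share one core, a threonine-derived amide carrying a long saturated chain, and differ at two places. Compound 1 `CCCCCCCCCCCCNC(=O)[C@@H](NC(=O)c1cc2ccccc2o1)[C@@H](C)O` bears the shorter chain and the 1-benzofuran-2-yl group; in a functional assay on HepG2 cells (Homo sapiens) for cytotoxicity, read by MTT assay, with a stated time of 48 h (a lower number here means a stronger inhibitor, a higher number a weaker inhibitor), compound 1 gives 22900 nM. Compound 2 `CCCCCCCCCCCCNC(=O)[C@@H](NC(=O)c1nccc2ccccc12)[C@@H](C)O` differs from it by isoquinolin-1-yl in place of 1-benzofuran-2-yl on a carbonyl carbon. In this assay compound 2 gives 65700 nM, which is a 2.9-fold higher number from compound 1 to compound 2 (0.46 log units; beyond the scatter). Compound 3 `CCCCCCCCCCCCCCCCCCNC(=O)[C@@H](NC(=O)c1cc2ccccc2o1)[C@@H](C)O` differs from compound 1 by hexyl in place of hydrogen on a saturated chain carbon, ten or more bonds along the chain from an amide-type nitrogen. Compound 3 reaches only a limit of the assay, and in this assay compound 3 gives > 200000 nM. The lengthening of the chain thus reads as an at least 8.7-fold higher number from compound 1 to compound 3 (0.94 log units; beyond the scatter).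

Compound 4 `CCCCCCCCCCCCCCCCCCNC(=O)[C@@H](NC(=O)c1nccc2ccccc12)[C@@H](C)O` has not yet been measured. It differs from compound 3 by isoquinolin-1-yl in place of 1-benzofuran-2-yl on a carbonyl carbon, the same change as that from compound 1 to compound 2, made at the same place. Between compound 1 and compound 2 that change produced a modest weakening. Because compound 3 already sits at the limit of > 200000 nM in this assay, at which 1 of the 3 values shown sits, the same change on compound 3 would move compound 4 still further beyond that limit. The step from compound 3 to compound 4 is expected to be a step that the limit leaves unreadable from compound 3 to compound 4. Compound 4 is expected to give 400000 nM, most likely reported again only as a limit, within an expected range from 200000 nM to 1000000 nM.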

Compound 4, half-maximal inhibitory concentration: 96900 nM
The estimate for compound 4 lay 4.1-fold (0.62 log units) above the measured number; measured number outside the range, below it.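

In this assay, putting isoquinolin-1-yl in place of 1-benzofuran-2-yl on the longer chain gives an at least 2.0-fold lower number from compound 3 to compound 4 (0.31 log units; beyond the scatter), so the change does not keep its direction when carried from the shorter-chain core of compound 1 to the longer-chain core of compound 3: the same change on two cores in this assay, a 2.9-fold higher number (0.46 log units; beyond the scatter) from compound 1 to compound 2 and an at least 2.0-fold lower number (0.31 log units; beyond the scatter) from compound 3 to compound 4, at least 5.9-fold (0.77 log units) apart, beyond the scatter of two such steps. Read along the other edge of the set, the added hexyl gives a 1.5-fold higher number from compound 2 to compound 4 (0.17 log units; within the scatter), and the same chain extension therefore also differs between the two cores: the same change on two cores in this assay, an at least 8.7-fold higher number (0.94 log units; beyond the scatter) from compound 1 to compound 3 and a 1.5-fold higher number (0.17 log units; within the scatter) from compound 2 to compound 4, at least 5.9-fold (0.77 log units) apart, beyond the scatter of two such steps. Across these four compounds, the effect of one place depends on what sits at the other, but this does not show why, and the full size of the gap stays unknown, as one of its ends is only a limit: the limit of > 200000 nM in this assay, at which 1 of the 4 values shown sits.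

The compounds shown leave open where between the two chain lengths the effect of the change turns round, a question that a tetradecyl chain could help to answer. They also leave open whether the same turn-around would appear with another group on the carbonyl carbon, such as quinolin-2-yl.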